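A few compounds are considered here, and "the series" means these few. Any claim that something is new, unique, unknown or untested is made for them only; others in the source may bear on it.

Measured compounds:
- Compound 1 `Brc1cccc(Br)c1N(CC1CC1)C1=NCCN1` — -1.12
- Compound 2 `CC(C)N(C1=NCCN1)c1c(Br)cccc1Br` — -0.82
- Compound 3 `Brc1cccc(Br)c1N(CC1CCC1)C1=NCCN1` — -0.06

In a physicochemical assay for lipophilicity (a higher number here means a more lipophilic compound, a lower number a more polar compound), compound 1 gives the lowest of the three numbers. Its nearest neighbour is compound 2, and the step of a number 0.30 log units higher from compound 1 to compound 2 (within the scatter) falls within the scatter, so the two cannot be ranked. The step of a number 1.06 log units higher from compound 1 to compound 3 (beyond the scatter) is beyond the scatter and large, and the step of a number 0.76 log units higher from compound 2 to compound 3 (beyond the scatter) is beyond the scatter as well.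

Compound 4 `Brc1cccc(Br)c1N(C1=NCCN1)C1CCCC1` has not yet been measured. Compared with compound 1 the change is cyclopentyl in place of cyclopropylmethyl on a nitrogen on an aromatic ring.

The step that bears most directly on this is a number 1.06 log units higher from compound 1 to compound 3 (beyond the scatter), where one extra ring carbon was enough for a large rise. Compound 4 carries the same count of carbon atoms as compound 3, but arranged as a single ring attached straight to the nitrogen, so a rise of roughly that size, though perhaps somewhat smaller, is expected in this assay, giving a number 0.97 log units higher from compound 1 to compound 4 (beyond the scatter).

Compound 4 is therefore estimated at -0.15 in this assay, with a range from -0.75 to 0.45.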

Compound 4, distribution coefficient: -0.29
Beside the measured number, compound 4's estimate is 0.14 log units above it, within the range that was stated.
By their numbers in this assay, from the lowest: compounds 1 and 2 (each within the scatter of the next); then compounds 4 and 3 (each within the scatter of the next).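

In this assay, cyclopentyl on a nitrogen on an aromatic ring sets compound 4 clearly apart from the cyclopropylmethyl group of compound 1, with a number 0.83 log units higher from compound 1 to compound 4 (beyond the scatter), and from the isopropyl group of compound 2, with a number 0.53 log units higher from compound 2 to compound 4 (beyond the scatter). Against the cyclobutylmethyl group of compound 3, the result is a number 0.23 log units lower from compound 3 to compound 4 (within the scatter), so these two compounds cannot be ranked, and the four compounds fall into a lower pair, compounds 1 and 2, and an upper pair, compounds 3 and 4. No measurement available here gives a reason for this split.

The compounds shown leave open whether a cyclohexyl group at this position would continue the rise seen from the lower pair to the upper pair, or whether an open pentyl chain would land with the upper pair as the two ring-bearing groups of compounds 3 and 4 do. They also leave open how far the number in this assay would move with an amine or a methoxyethyl group on the same nitrogen, since every group shown here is built of carbon only.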